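A few compounds are considered here, and "the series" means these few. Any claim that something is new, unique, unknown or untested is made for them only; others in the source may bear on it.

Working notes on the series. Among the measured compounds shown here, in an in vitro assay on 293-EBNA cells for binding affinity to corticotropin-releasing factor receptor 1 (Homo sapiens) (a higher number here means a weaker inhibitor, a lower number a stronger inhibitor), compound 2 `CCC(COC)Oc1nc(C)nc2c1nnn2-c1ccc(C(C)C)cc1Br` gives 1.9 nM, the lowest of the two numbers so far; its nearest neighbour is compound 1 `CCC(COC)N(C)c1nc(C)nc2c1nnn2-c1ccc(C(C)C)cc1Br`, which in this assay gives 11.2 nM, with a 5.9-fold lower number from compound 1 to compound 2 (0.77 log units; beyond the scatter). Compound 3 `CCOCC(COCC)Oc1nc(C)nc2c1nnn2-c1ccc(C(C)C)cc1Br` is not yet measured; it differs from compound 2 in that (2-ethoxy-1-(ethoxymethyl)ethyl in place of 1-(methoxymethyl)propyl on an oxygen on an aromatic ring). For the measured compounds named here, the one measured step concerns the atom joining the side chain to the core, not the chain itself, so nothing measured bears directly on this change. A step within the scatter, or a small rise, is therefore expected: a 1.7-fold higher number from compound 2 to compound 3 (0.23 log units; within the scatter). For compound 3 in this assay the estimate is 3.2 nM, between 1 nM and 10 nM.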

Compound 3, inhibition constant: 39.7 nM
The estimate for compound 3 lay 12-fold (1.09 log units) below the measured number, and the stated range ends below it.
By their numbers in this assay, from the lowest: compound 2; then compound 1; then compound 3.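

In this assay the chain on the oxygen on the aromatic ring matters as much as the linking atom: 2-ethoxy-1-(ethoxymethyl)ethyl in place of 1-(methoxymethyl)propyl gives a 21-fold higher number from compound 2 to compound 3 (1.32 log units; beyond the scatter) in this series. The gain seen with the oxygen link therefore does not carry over to every chain, with a 3.5-fold higher number from compound 1 to compound 3 (0.55 log units; beyond the scatter) against the nitrogen-linked compound. No measurement at hand accounts for this loss.

The size of the chain and its added hydrogen-bond acceptor change together here, so their contributions cannot be separated. A 2-methoxy-1-(methoxymethyl)ethyl chain or a plain pentyl chain on the same oxygen remains an open case.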